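Three Limits and a Fluoroethyl Ether Still to Test

The source may report more compounds than this note shows. Statements on the series, on what has been measured and on what is new or still open speak of the compounds shown alone.

Measured in an assay on isolated protein for inhibition of Caspase-8 (Homo sapiens); a lower number here means a stronger inhibitor, a higher number a weaker inhibitor:
Compound 1 `COC[C@@H]1CCCN1S(=O)(=O)c1ccc2c(c1)C(=O)C(=O)N2C` gives > 500000 nM.
Compound 2 `COC[C@@H]1CCCN1S(=O)(=O)c1ccc2c(c1)C(=O)C(=O)N2Cc1ccc(O)cc1` gives > 500000 nM.
Compound 3 `COC[C@@H]1CCCN1S(=O)(=O)c1ccc2c(c1)C(=O)C(=O)N2Cc1ccc(OCCOS(=O)(=O)c2ccc(C)cc2)cc1` gives > 500000 nM.

Each of these three values is a limit of the assay, not a number. Compound 2 therefore stands at the limit, and so do its two neighbours, which leaves the step from compound 1 to compound 2 unreadable: a step that the two limits leave unreadable from compound 1 to compound 2. Compound 4 `COC[C@@H]1CCCN1S(=O)(=O)c1ccc2c(c1)C(=O)C(=O)N2Cc1ccc(OCCF)cc1` differs from compound 2 by 2-fluoroethyl in place of hydrogen on an oxygen on an aromatic ring. Among the measured compounds shown here, no measured step bears on this change, and all three values sit at one place: the limit of > 500000 nM in this assay, at which 3 of the 3 values shown sit. The expectation is that compound 4 also stays at the limit, a step from compound 2 to compound 4 of a number no higher from compound 2 to compound 4 (the limit leaves the size open). Compound 4 is estimated at 500000 nM, with a range from 100000 nM to 2000000 nM.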

Compound 4, half-maximal inhibitory concentration: > 25000 nM
Compound 4 ended at the assay's limit; the forecaster's own chance of this, stated with the estimate: 90%; the middle value does not contradict the limit.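

In this assay compound 4 gives > 25000 nM, which is a limit and not a number. Its steps from compound 1, compound 2 and compound 3 therefore cannot be read. The compounds shown leave open whether any change here alters inhibition at all.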